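This account rests on a few compounds, and the source may have more. Where it says the series, first, only, none or still open, it means among the compounds named here.

Measured compounds: compound 2 `C1=C(c2cccnc2)C[C@H]2CNC[C@@H]1C2` gives 100 nM in an in vitro functional assay on SH-EP1 cells for agonist activity at Neuronal acetylcholine receptor; alpha4/beta2 (Homo sapiens), read by voltage clamp; on this read-out lower numbers stand for an effect already at smaller amounts and higher numbers for an effect only at larger amounts of compound; compound 1 `CN1C[C@H]2C=C(c3cccnc3)C[C@H](C2)C1` gives 3500 nM.

Compound 2 holds the lower of the two numbers in this assay; the step of a 35-fold lower number from compound 1 to compound 2 (1.54 log units; beyond the scatter) came from hydrogen in place of methyl on an amine nitrogen in a ring. Compound 3 `C1=C(c2cccnc2)C[C@@H]2CNC[C@H]1C2` differs from compound 2 as follows: the two compounds have the same atoms and bonds and differ only in configuration as drawn: 2 of 2 stereo elements differ (all stereocentres are inverted: mirror images); a stereocentre at a saturated ring carbon is drawn S in compound 2 and R in compound 3; a stereocentre at a saturated ring carbon is drawn R in compound 2 and S in compound 3. No measured step concerns a change of configuration, so the one step shown gives no guide, and neither direction can be set. Compound 3 is therefore expected near compound 2, about 250 nM, within 50 nM to 3000 nM, a step of a 2.5-fold higher number from compound 2 to compound 3 (0.40 log units; beyond the scatter).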

Compound 3, half-maximal effective concentration: 50 nM
For compound 3 the middle estimate is 5.0-fold (0.70 log units) above the measured one, and the stated range covers the measured number.
By their numbers in this assay, from the lowest: compounds 3 and 2 (each within the scatter of the next); then compound 1.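

In this assay the change to the mirror image gives a 2.0-fold lower number from compound 2 to compound 3 (0.30 log units; within the scatter), so inverting both stereocentres does not separate the two compounds beyond repeated measurement. This is a far smaller shift than the one seen at the ring nitrogen, a 35-fold lower number from compound 1 to compound 2 (1.54 log units; beyond the scatter). The comparison therefore concerns configuration alone: the fact that compounds 2 and 3 differ only in the configuration as drawn

The compounds shown leave open whether a methyl on the ring nitrogen has the same effect in the mirror-image series. They also leave open how an ethyl group or a longer chain on that nitrogen would read in this assay.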